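Saturating the side chain of a weak urea

The compounds below may be only part of what the source reports. "The series", "measured", "known", "first", "only" and "open" are said of these compounds alone.

Measured in a functional assay on KETR3 cells (Homo sapiens) for inhibition, read by MTT assay, with a stated time of 120 h; a higher number here means a weaker inhibitor, a lower number a stronger inhibitor:
Compound 1 `CC1CN(C(=O)c2ccc(-c3ccc(NC(=O)Nc4ccc(Cl)c(C(F)(F)F)c4)cc3)cc2)CC(C)O1`: 41900 nM
Compound 2 `CC(NC(=O)/C=C/c1ccc(NC(=O)Nc2ccc(Cl)c(C(F)(F)F)c2)cc1)c1ccccc1`: 21200 nM
Compound 3 `CNC(=O)/C(C)=C/c1ccc(NC(=O)Nc2ccc(Cl)c(C(F)(F)F)c2)cc1`: > 50000 nM

Compound 3 is the only one of the three without a number. In this assay compound 3 reads > 50000 nM, and that value is a limit of the assay.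

Compound 4 `CNC(=O)CCc1ccc(NC(=O)Nc2ccc(Cl)c(C(F)(F)F)c2)cc1` has 2-(methylcarbamoyl)ethyl in place of 2-(methylcarbamoyl)prop-1-en-1-yl on an aromatic carbon, para to a large group: 2-(methylcarbamoyl)ethyl in place of 2-(methylcarbamoyl)prop-1-en-1-yl on an aromatic carbon.

Among the compounds with values here, no two measured compounds differ in one place, so the data give no direct size for such a change. The expectation rests on the two compounds with numbers: compound 1 gives 41900 nM and compound 2 gives 21200 nM, and these two lie within the usual scatter of each other. The expected step is modest, towards a lower number or none beyond the scatter: an at least 1.2-fold lower number from compound 3 to compound 4 (0.09 log units; that floor lies within the scatter). For compound 4 the estimated value is 40000 nM, with an expected range from 15000 nM to 60000 nM.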

Compound 4, half-maximal inhibitory concentration: 24000 nM
Compound 4: the middle estimate sits 1.7-fold (0.22 log units) above what was measured; the measured number falls inside the stated range.
By their numbers in this assay, from the lowest: compounds 2, 4 and 1 (each within the scatter of the next). At a limit, above all of these: compound 3.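

Within the data shown here, putting 2-(methylcarbamoyl)ethyl in place of 2-(methylcarbamoyl)prop-1-en-1-yl on this aromatic carbon gives the first step that can be read in this set: in this assay the change amounts to an at least 2.0-fold lower number from compound 3 to compound 4 (0.31 log units; beyond the scatter). The saturated side chain therefore gives a measured number, whereas the unsaturated chain of compound 3 gives only a limit. That step is a floor rather than a full size, because one of its two ends is a limit: the limit of > 50000 nM in this assay, at which 1 of the 4 values shown sits.

The change removes both the chain double bond and the methyl on that chain, so the compounds shown do not separate the contribution of each. They also leave open how a longer chain, or a carboxylic acid or an amine in place of the methylcarbamoyl group, would read at this position.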